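From 4-methylbenzyl to 4-fluorobenzyl in a growth assay

The compounds below may be only part of what the source reports. "The series", "measured", "known", "first", "only" and "open" are said of these compounds alone.

Measured in a functional assay on DU-145 cells (Homo sapiens) for inhibition, read by trypan blue exclusion, with a stated time of 96 h; on this read-out lower numbers stand for stronger inhibition of growth and higher numbers for weaker inhibition of growth:
- compound 1 `COc1ccccc1/C=C(/SCc1ccc(F)cc1)C(=O)c1ccc(Cl)cc1`: 10000 nM
- compound 2 `Cc1ccc(CS/C(=C/c2ccc(Br)cc2)C(=O)c2ccc(Cl)cc2)cc1`: 10000 nM
- compound 3 `Cc1ccc(CS/C(=C/c2c[nH]c3ccc(Cl)cc23)C(=O)c2ccc(Cl)cc2)cc1`: 1000 nM

Compound 2 stands level with compound 1 at the digits reported, and together they hold the highest number of the three. Within the data shown here, compound 3 lies well under that pair, and a 10-fold lower number from compound 2 to compound 3 (1.00 log units; beyond the scatter) is the only measured step. That step replaces 4-bromophenyl with 5-chloro-1H-indol-3-yl, so it concerns a different place from the one at issue here.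

Compound 4 `O=C(/C(=C\c1ccc(Br)cc1)SCc1ccc(F)cc1)c1ccc(Cl)cc1` keeps the 4-bromophenyl of compound 2 and changes only the benzyl group: fluoro in place of methyl on an aromatic carbon. This turns 4-methylbenzyl into 4-fluorobenzyl. Among the measured compounds shown here, no measured step covers this exchange, so the evidence is indirect. Compound 1 already carries 4-fluorobenzyl and gives 10000 nM, though it differs from compound 4 elsewhere too. For the measured compounds named here, with that value as the only guide, no shift beyond the scatter is expected in this assay. The expected change is the no change at the digits printed from compound 2 to compound 4 (within the scatter). For compound 4 the estimated value is 10000 nM, with an expected range of 5000 nM to 20000 nM.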

Compound 4, concentration for 50% growth inhibition: 9000 nM
Beside the measured number, compound 4's estimate is 1.1-fold (0.05 log units) above it; low and high end bracket the measured number.
By their numbers in this assay, from the lowest: compound 3; then compounds 4, 1 and 2 (each within the scatter of the next).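

In this assay the exchange of 4-methylbenzyl for 4-fluorobenzyl now has a direct reading, and a 1.1-fold lower number from compound 2 to compound 4 (0.05 log units; within the scatter) lies within the scatter, so with 4-bromophenyl held in place, fluoro and methyl on this aromatic carbon cannot be told apart. Compound 4 also links compound 1 to the rest of the series: a 1.1-fold lower number from compound 1 to compound 4 (0.05 log units; within the scatter) is likewise within the scatter, so with 4-fluorobenzyl held in place, 4-bromophenyl and 2-methoxyphenyl cannot be told apart either. No independent data are available to explain why these two exchanges leave the number within the scatter.

From the compounds shown here alone, both new steps were read among compounds near the top of the range, so it remains open whether the same exchange would also stay within the scatter on the 5-chloro-1H-indol-3-yl compound, compound 3, which gives 1000 nM in this series. The compounds shown also leave open how a group such as an amine, a carboxylic acid or a longer chain would behave at this position on the benzyl ring.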